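Step from compound 3 to compound 4: removing the ester group

The source may hold more compounds than are shown below. What is called first, only, known or untested is meant among the compounds shown, and "the series" means these compounds.

Three compounds sharing one core have numbers in an ADME assay on cells (Hepatocyte, Mus musculus) for metabolic stability, with a stated time of 30 min (on this read-out higher numbers stand for a more stable compound and lower numbers for a less stable compound), so far. Compound 1 (`O=C(NC1CCC(CN2CCN(c3cc(=O)c4cc(C(F)(F)F)cc([N+](=O)[O-])c4s3)CC2)CC1)c1ccccc1`) gives 90.6% and compound 2 (`O=C(OC1CCC(CN2CCN(c3cc(=O)c4cc(C(F)(F)F)cc([N+](=O)[O-])c4s3)CC2)CC1)c1ccco1`) gives 0.6% while compound 3 (`O=C(OC1CCC(CN2CCN(c3cc(=O)c4cc(C(F)(F)F)cc([N+](=O)[O-])c4s3)CC2)CC1)C1CCCCC1`) gives 1.2% on this read-out. Compound 3 therefore stands level with compound 2 and far under compound 1.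

Compound 4 (`O=c1cc(N2CCN(CC3CCCCC3)CC2)sc2c([N+](=O)[O-])cc(C(F)(F)F)cc12`) has hydrogen in place of (cyclohexylcarbonyl)oxy on a saturated ring carbon. For the measured compounds named here, no measured compound carries hydrogen there, so the step is an extrapolation.

Going by the values given here, two measured steps bear on it. The step of a number 90 percentage points lower from compound 1 to compound 2 (beyond the scatter) and the step of a number 89.4 percentage points lower from compound 1 to compound 3 (beyond the scatter) are both large, and each puts a carbonyl-oxy group in place of benzamido. The step of a number 0.6 percentage points higher from compound 2 to compound 3 (within the scatter) shows no separation between the two groups on the carbonyl carbon. Among these three compounds, the low numbers go with the carbonyl-oxy groups, and none goes against this. Compound 4 lacks such a group, so a large upward step is expected, though compound 4 also lacks the benzamido of compound 1, which leaves the size uncertain.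

For compound 4 the estimated change is a number 68.8 percentage points higher from compound 3 to compound 4 (beyond the scatter) and the size remains an expectation only. For compound 4 the estimated value is 70% with an expected range from 35% to 95% in this assay.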

Compound 4, percent of the compound remaining: 80.6%
Compound 4: middle estimate off by 10.6 percentage points, on the low side, and the stated range covers the measured number.
By their numbers in this assay, from the lowest: compounds 2 and 3 (each within the scatter of the next); then compounds 4 and 1 (each within the scatter of the next).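

In this assay the replacement of the carbonyl-oxy group by hydrogen on the saturated ring carbon gives a number 79.4 percentage points higher from compound 3 to compound 4 (beyond the scatter) and also a number 80 percentage points higher from compound 2 to compound 4 (beyond the scatter), so the low numbers of compound 2 and compound 3 go with the presence of these groups and not with the rest of the molecule. The shared core and the piperazine-linked cyclohexylmethyl part therefore give a high number without any substituent at this position, and a number 10 percentage points lower from compound 1 to compound 4 (within the scatter) leaves hydrogen and benzamido unseparated here, which means the benzamido of compound 1 is not needed for the high number. Nothing available says why the carbonyl-oxy compounds stand so low.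

The compounds shown cover only hydrogen, benzamido and two carbonyl-oxy groups at this position, so it remains open how a hydroxyl, an ether, a carbamate or a primary amine would read here. As far as these compounds go, with just one amide in the set, it is also open whether amides other than benzamido, such as a furan-2-carboxamide or a cyclohexanecarboxamide, stay as high as compound 1 in this assay and whether the group on the carbonyl carbon matters there.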